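A smaller carboxy ring on compound 2

The source may hold more compounds than are shown below. What is called first, only, known or untested is meant among the compounds shown, and "the series" means these compounds.

Compound 1 `COc1ccc(/C=C\c2cc(OC)c(OC)c(OC)c2)cc1OCc1ccc(CN2CCCC[C@H]2C(=O)O)cc1`: > 10000 nM, a limit
Compound 2 `COc1ccc(/C=C\c2cc(OC)c(OC)c(OC)c2)cc1OCc1ccc(CN2CCCC[C@@H]2C(=O)O)cc1`: > 10000 nM, a limit
Compound 3 `COc1ccc(/C=C\c2cc(OC)c(OC)c(OC)c2)cc1OCc1ccc(CN2CCCCC2C(=O)NCCNC(=O)OC(C)(C)C)cc1`: 4700 nM

These values come from a functional assay on B16-F10 cells (Mus musculus) for antiproliferative activity, read by CCK-8 assay, with a stated time of 48 h; on this read-out higher numbers stand for weaker inhibition and lower numbers for stronger inhibition. Compound 2 gives > 10000 nM, which is a limit and not a number. Compound 1 shares this position, and together they sit at the limit of > 10000 nM in this assay, at which 2 of the 3 values shown sit. Among the compounds with values here, compound 3 gives 4700 nM, the only true number so far, and it has no free carboxy group.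

The next structure is compound 4 `COc1ccc(/C=C\c2cc(OC)c(OC)c(OC)c2)cc1OCc1ccc(CN2CC(C(=O)O)C2)cc1`, which has not yet been measured. The change from compound 2 is 3-carboxyazetidin-1-yl in place of 2-carboxypiperidin-1-yl on a saturated chain carbon bound to an aromatic carbon. In words, 3-carboxyazetidin-1-yl takes the place of 2-carboxypiperidin-1-yl on a saturated chain carbon bound to an aromatic carbon.

Within the data shown here, only one measured step bears on this change, and it is a step that the two limits leave unreadable from compound 1 to compound 2. It concerns (the fact that compounds 1 and 2 differ only in the configuration as drawn), so it offers no size to carry over to a change of ring. Compound 4 keeps a free carboxy group, so it is expected to stay close to compound 2 at > 10000 nM, itself a limit. No clear step is therefore expected in this assay, and the assay will most likely report a limit again. The expected step is a step that the limit leaves unreadable from compound 2 to compound 4. For compound 4 the estimated value is 12000 nM, with an expected range of 6000 nM to 30000 nM.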

Compound 4, half-maximal inhibitory concentration: > 10000 nM
Compound 4: no number, only a limit; the forecaster's own chance of this, stated with the estimate: 85%; the middle value lies beyond the limit too.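

In this assay compound 4 gives > 10000 nM, which is a limit and not a number. Compound 1 and compound 2 also sit at limits, so the steps from either of them to compound 4 cannot be read. The compounds shown leave open whether 3-carboxyazetidin-1-yl and 2-carboxypiperidin-1-yl differ at all in this assay.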